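The source may report more compounds than this note shows. Statements on the series, on what has been measured and on what is new or still open speak of the compounds shown alone.

Compound 1 `COc1ccc(/C(=N/O)c2cccc3ccccc23)c(OC)c1OC` was tested in a functional assay on A549 cells (Homo sapiens) for inhibition, read by sulforhodamine B assay, with a stated time of 48 h (a lower number here means a stronger inhibitor, a higher number a weaker inhibitor), and gives 13100 nM. Among the compounds with values here, that is the higher of the two numbers measured so far. The other measured compound, compound 2 `COc1ccc(C(O)(Cc2ccc(F)cc2)c2cccc3ccccc23)c(OC)c1OC`, gives 5940 nM in this assay, a value that stands apart from compound 1 by more than the usual scatter, so compound 2 is the stronger inhibitor of the pair. Compound 3 `COc1ccc(/C(=N/OCC(=O)O)c2cccc3ccccc23)c(OC)c1OC` is built from compound 1 by a single change: carboxymethyl in place of hydrogen on an oxygen. Within the data shown here, no measured pair shows what this change does in this assay, so the direction of the step is open. For compound 3 the expected step is a 1.5-fold higher number from compound 1 to compound 3 (0.18 log units; within the scatter), a mild weakening or no step beyond the scatter. Compound 3 is therefore expected to reach about 20000 nM in this assay, with a plausible range from 6000 nM to 60000 nM.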

Compound 3, half-maximal inhibitory concentration: 17200 nM
Compound 3: middle estimate off by 1.2-fold (0.07 log units), on the high side, within the range that was stated.
By their numbers in this assay, from the lowest: compound 2; then compounds 1 and 3 (each within the scatter of the next).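

Until compound 3, nothing showed whether the oxygen on the double-bonded nitrogen could carry anything other than hydrogen. In this assay, placing carboxymethyl on that oxygen gives a 1.3-fold higher number from compound 1 to compound 3 (0.12 log units; within the scatter) and so leaves the two numbers within the scatter of each other. The position therefore tolerates this added chain without a measurable loss or gain, though both compounds remain weak inhibitors on the scale of the numbers seen so far, and no measurement here offers an explanation for the outcome.

A single substitution cannot show whether this tolerance extends to other groups at this oxygen, such as a plain methyl, an aminoethyl chain or a longer carboxylic acid chain. It also leaves open whether the carboxylic acid end of carboxymethyl contributes anything, or whether a chain of any kind would give a similar number.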